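A phenyl for a bromo on the aryl ketone

The source may hold more compounds than are shown below. What is called first, only, known or untested is meant among the compounds shown, and "the series" means these compounds.

Measured compounds:
compound 1 `CC(=O)c1ccc(Nc2ccnc(SCC(=O)c3ccc(Br)cc3)n2)cc1` gives 12%
compound 2 `CCOC(=O)c1ccc(Nc2ccnc(SCC(=O)c3ccc(C#N)cc3)n2)cc1` gives 21%

Both were tested in a functional assay on IGROV-1 cells (Homo sapiens) for inhibition, read by sulforhodamine B assay, with a stated time of 48 h, tested at 10 uM; on this read-out lower numbers stand for less inhibition of growth and higher numbers for more inhibition of growth at the one concentration tested. Compound 1 stands at one end of the two numbers, but its gap to compound 2 lies within the usual scatter, so the two cannot be told apart on these data.

Compound 3 `CC(=O)c1ccc(Nc2ccnc(SCC(=O)c3ccc(-c4ccccc4)cc3)n2)cc1` has not yet been measured. It differs from compound 1 in one place: phenyl in place of bromo on an aromatic carbon. No step between two measured compounds covers a change of this kind, so there is nothing to lean on beyond the two numbers shown. Both of those sit low on the read-out, and nothing here points to a larger shift in either direction.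

Compound 3 is therefore expected to stay near compound 1, with a step of a number 6 percentage points higher from compound 1 to compound 3 (within the scatter) in this assay that stays within the scatter. The value of compound 3 is estimated at 18%, in a range from 0% to 45%.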

Compound 3, percent growth inhibition at one concentration: 14%
Estimate against measurement, compound 3: 4 percentage points above, and the stated range covers the measured number.
By their numbers in this assay, from the lowest: compounds 1, 3 and 2 (each within the scatter of the next).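

In this assay, phenyl in place of bromo on an aromatic carbon, para to a large group, gives a number 2 percentage points higher from compound 1 to compound 3 (within the scatter). Going by these compounds alone, this is the first comparison here that isolates a single change, since compound 1 and compound 2 differ in more than one place. It shows that a group of 6 heavy atoms carrying a six-membered aromatic ring, set where a single bromine stood, leaves the growth inhibition indistinguishable at the one concentration tested, with compound 3 at 14%. No evidence is at hand that bears on this result.

On these data alone, it remains open whether an amine or a carboxylic acid at this position would move the number beyond the scatter. Equally open, as far as these compounds go, is whether a longer chain in this place would do so.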